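Replacing the amino group of compound 3 with a longer chain

This account rests on a few compounds, and the source may have more. Where it says the series, first, only, none or still open, it means among the compounds named here.

In a functional assay on the whole organism for antagonist activity, with Mus musculus as the target (on this read-out lower numbers stand for an effect already at smaller amounts and higher numbers for an effect only at larger amounts of compound), compound 1 (`CC(=O)N(c1ccccc1)C1CCCC1N(C)C`) gives 9 mg/kg as its dose, compound 2 (`CCC(=O)N(c1ccc(F)c(Cl)c1)C1CCCC1N(C)C`) gives 2 mg/kg as its dose, and compound 3 (`CCC(=O)N(c1ccc(Cl)c(Cl)c1)C1CCCC1N`) gives 0.8 mg/kg as the lowest number of the three. Compound 4 (`CCC(=O)N(c1ccc(Cl)c(Cl)c1)C1CCCC1N(C)CCN(C)C`) carries (2-(dimethylamino)ethyl)(methyl)amino in place of amino on a saturated ring carbon of compound 3 ((2-(dimethylamino)ethyl)(methyl)amino in place of amino on a saturated ring carbon). No measured pair differs in one place alone, so the size of this change is not shown directly. Compound 2, which also has no plain amino group, stands higher at 2 mg/kg but differs elsewhere too. The expected change is a 5.0-fold higher number from compound 3 to compound 4 (0.70 log units; beyond the scatter) in this assay toward a higher number, though this is uncertain. For compound 4 the estimated value is 4 mg/kg with an expected range from 1 mg/kg to 20 mg/kg overall.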

Compound 4, dose for half-maximal effect: 5 mg/kg
For compound 4 the middle estimate is 1.3-fold (0.10 log units) below the measured one, and the stated range covers the measured number.
By their numbers in this assay, from the lowest: compound 3; then compound 2; then compounds 4 and 1 (each within the scatter of the next).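

In this assay, within the data shown here, the step from amino to (2-(dimethylamino)ethyl)(methyl)amino on this saturated ring carbon is a 6.3-fold higher number from compound 3 to compound 4 (0.80 log units; beyond the scatter) and is the only step here that isolates this position. It shows that the number responds to what this carbon carries, and that the larger group raises the dose without removing the effect. Nothing given here accounts for the size of this step. Still open, going by these compounds, is whether a smaller methylamino group on the same carbon would already raise the number, or whether that takes the longer chain.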